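Amidine chain homologue in the inducible nitric oxide synthase series

The compounds below may be only part of what the source reports. "The series", "measured", "known", "first", "only" and "open" are said of these compounds alone.

Measured so far:
compound 1 `COCCC(=N)NCCC[C@H](N)C(=O)O`: 50%
compound 2 `COCCC(=N)NCCCCN`: 16%

In an assay on isolated protein for inhibition of Nitric oxide synthase, inducible (Homo sapiens), read by spectrophotometry, using NADPH, tested at 1 mM, in the presence of a further agent that is not named here (on this read-out higher numbers stand for more inhibition at the one concentration tested (going by the name of the read-out) and lower numbers for less inhibition), compound 2 gives 16%, the lowest of the two numbers measured; its nearest neighbour is compound 1, and the step of a number 34 percentage points lower from compound 1 to compound 2 (beyond the scatter) is the only one measured, with hydrogen in place of carboxy on a saturated chain carbon bound to an amine nitrogen and a saturated chain carbon.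

Compound 3 `COCCCC(=N)NCCCCN` is not yet measured. Relative to compound 2 the change is methoxymethyl in place of methoxy on a saturated chain carbon, two bonds along the chain from a carbon with a double bond to nitrogen. Among the compounds with values here, no measured step touches this part of the molecule, so the carboxy step gives no guidance on it; the change is confined to the chain carrying the methoxy group and leaves the rest of compound 2 untouched.

For compound 3 the step from compound 2 is therefore expected to be small, a number 2 percentage points higher from compound 2 to compound 3 (within the scatter), not beyond the scatter in either direction. Compound 3 is estimated at 18%, between 5% and 35%.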

Compound 3, a percentage reported as inhibition, at one concentration (the size of the read-out at that concentration, not a potency): 15%
For compound 3 the middle estimate is 3 percentage points above the measured one; the range from low to high includes it.
By their numbers in this assay, from the lowest: compounds 3 and 2 (each within the scatter of the next); then compound 1.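

In this assay, within the data shown here, exchanging methoxy for methoxymethyl on a saturated chain carbon, two bonds along the chain from a carbon with a double bond to nitrogen, gives a number 1 percentage points lower from compound 2 to compound 3 (within the scatter), the first reading at this position. Among these compounds, compound 2 and compound 3 cannot be told apart here, so this position accepts the exchange without a step beyond the scatter, at least in compounds lacking the carboxy group, whereas the only step beyond the scatter so far is the carboxy step. Nothing measured explains either step.

The compounds shown leave open whether methoxymethyl behaves the same way on the core of compound 1, where the carboxy group is present. They also leave open how a 2-methoxyethyl, ethoxy or hydroxymethyl group would read at this position.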